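A Dichlorophenyl in Place of Methoxyphenyl: Expected Cytotoxicity

The compounds below may be only part of what the source reports. "The series", "measured", "known", "first", "only" and "open" are said of these compounds alone.

Measured compounds:
Compound 1 `O=C(/C=C/c1ccc([N+](=O)[O-])o1)c1ccc(OCc2ccc(F)cc2)cc1` gives 430000 nM in a toxicity assay on Vero cells (Chlorocebus sabaeus) for cytotoxicity; a lower number here means that less compound is tolerated, a higher number that more compound is tolerated.
Compound 2 `COc1ccc(COc2ccc(C(=O)/C=C/c3ccc([N+](=O)[O-])o3)cc2)cc1` gives 311000 nM in this assay.

Compound 2 holds the lower of the two numbers measured in this assay, but its separation from compound 1 is small: a 1.4-fold lower number from compound 1 to compound 2 (0.14 log units; within the scatter), so the two cannot be told apart.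

Compound 3 `O=C(/C=C/c1ccc([N+](=O)[O-])o1)c1ccc(OCc2ccc(Cl)cc2Cl)cc1` differs from compound 2 in one place: 2,4-dichlorophenyl in place of 4-methoxyphenyl on a saturated chain carbon bound to an oxygen on an aromatic ring. Within the data shown here, the only measured step that touches this position is the one from compound 1 to compound 2, which exchanged a fluoro for a methoxy on that same aromatic carbon and stayed within the scatter. Among the measured compounds shown here, no measured pair shows what two chlorines on that ring do, and the change from compound 2 to compound 3 is larger than the one measured, since it also adds a second substituent.

With that thin basis, compound 3 is expected to land near compound 2 in this assay, with a somewhat lower number judged more likely than a higher one; the expected step is a 1.4-fold lower number from compound 2 to compound 3 (0.13 log units; within the scatter). The estimate for compound 3 is 230000 nM, with a range from 100000 nM to 500000 nM.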

Compound 3, half-maximal cytotoxic concentration: 340000 nM
For compound 3 the middle estimate is 1.5-fold (0.17 log units) below the measured one, within the range that was stated.
By their numbers in this assay, from the lowest: compounds 2, 3 and 1 (each within the scatter of the next).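

In this assay, 2,4-dichlorophenyl in place of 4-methoxyphenyl on a saturated chain carbon bound to an oxygen on an aromatic ring gives a 1.1-fold higher number from compound 2 to compound 3 (0.04 log units; within the scatter), and the same group in place of 4-fluorophenyl gives a 1.3-fold lower number from compound 1 to compound 3 (0.10 log units; within the scatter). The earlier compounds had shown only one substituent on this ring exchanged for another, whereas these two steps show that a ring with two chlorines also cannot be told apart from either ring with a single substituent, so all three compounds lie within the scatter of one another in this comparison. No supporting information bears on this result, and the reading therefore stays with the numbers alone.

The compounds shown leave open whether this sameness would hold for quite different groups on this ring, such as an amine or a carboxylic acid, or for a longer chain between the ring and the oxygen on the aromatic ring. All three compounds also share the same core, so they say nothing about whether changes elsewhere in the molecule would move the number in this assay.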